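Oxygen-linked aryl series: removing the methoxy from compound 3

A few compounds are considered here, and "the series" means these few. Any claim that something is new, unique, unknown or untested is made for them only; others in the source may bear on it.

Compound 1 `C1=C(c2cncc(OCc3ccccc3)c2)CC2CNCC1C2` gives 0.7 nM in an in vitro assay on SH-EP1 cells for displacement of a labelled ligand from Neuronal acetylcholine receptor; alpha4/beta2 (Homo sapiens); a higher number here means a weaker inhibitor, a lower number a stronger inhibitor. Compound 2 `CN1C[C@H]2C=C(c3cccnc3)C[C@H](C2)C1` gives 2.1 nM in this assay. Compound 3 `COc1ccccc1Oc1cncc(C2=CC3CNCC(C2)C3)c1` gives 1 nM in this assay, which is the second highest of the three numbers. Its nearest neighbour is compound 1, reached by a 1.4-fold higher number from compound 1 to compound 3 (0.15 log units; within the scatter), a step that stays within the scatter. Among the measured compounds shown here, the more distant number is that of compound 2, and the gap between compound 2 and compound 3 lies beyond the scatter; no single-point step connects those two.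

Compound 4 `C1=C(c2cncc(Oc3ccccc3)c2)CC2CNCC1C2` differs from compound 3 by hydrogen in place of methoxy on an aromatic carbon. For the measured compounds named here, no measured step removes a methoxy. Going by the values given here, the only recorded step, a 1.4-fold higher number from compound 1 to compound 3 (0.15 log units; within the scatter), exchanges the whole group on the oxygen and still moves the number within the scatter, so the series so far gives no sign that the aryl portion on that oxygen shifts this assay much. The change from compound 3 to compound 4 is a smaller edit than that exchange. The expected step is therefore a 1.1-fold higher number from compound 3 to compound 4 (0.04 log units; within the scatter), which is expected to stay within the scatter, with no clear direction. Compound 4 is expected to give 1.1 nM in this assay, with a range from 0.4 nM to 3 nM.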

Compound 4, inhibition constant: 0.7 nM
The estimate for compound 4 lay 1.6-fold (0.20 log units) above the measured number; measured number inside the range.
By their numbers in this assay, from the lowest: compounds 1, 4 and 3 (each within the scatter of the next); then compound 2.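

Taking the methoxy off the 2-methoxyphenyl group, on an aromatic carbon ortho to a large group, gives a 1.4-fold lower number from compound 3 to compound 4 (0.15 log units; within the scatter) in this assay; this is the first reading of that position alone, and the methoxy there is not required for a number in this range. Shortening the group on the oxygen from benzyl to phenyl gives no change at the digits printed from compound 1 to compound 4 (within the scatter) and, read with a 1.4-fold higher number from compound 1 to compound 3 (0.15 log units; within the scatter) for the exchange of benzyl for 2-methoxyphenyl, places all three groups on that oxygen within the scatter of one another, so this small set shows no preference among them. No independent measurement is available to explain this flat response.

From the compounds shown here alone, whether that flat response extends to other groups on the phenyl ring, such as an amine or a carboxylic acid, or to a longer chain between the oxygen and the ring, remains open. Also open, going by these compounds, is whether an amine link could stand in place of the oxygen link on the shared core without moving the number beyond the scatter.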